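The source may report more compounds than this note shows. Statements on the series, on what has been measured and on what is new or still open speak of the compounds shown alone.

Working notes on the series. In an ADME assay on HepG2 cells (Homo sapiens) for cytotoxicity (a higher number here means that more compound is needed for the effect, a lower number that less compound is needed), compound 1 `COc1cc(OC)cc(C(=O)NCCNC(=O)[C@H](CC(=O)NC(C)(C)C)NS(=O)(=O)c2ccc(C)cc2)c1` gives > 11000 nM as a limit of the assay. Compound 2 `Cc1ccc(S(=O)(=O)N[C@@H](CC(=O)NC(C)(C)C)C(=O)NCCNC(=O)c2cccc(C#N)c2)cc1` gives > 11000 nM which is also only a limit, and that is where compound 2 stands. So far the data hold only the limit of > 11000 nM in this assay, at which 2 of the 2 values shown sit, and no exact number. Going by the values given here, the one measured step is a step that the two limits leave unreadable from compound 1 to compound 2 and it concerns a group on a carbonyl carbon, the same place as the next change, but it offers no size to carry forward. Compound 3 `Cc1ccc(S(=O)(=O)N[C@@H](CC(=O)NC(C)(C)C)C(=O)NCCNC(=O)c2ccc(Cl)cc2)cc1` has 4-chlorophenyl in place of 3-cyanophenyl on a carbonyl carbon, counted as 4-chlorophenyl in place of 3-cyanophenyl on a carbonyl carbon in full. With no readable step to draw on, no shift beyond the scatter is expected in either direction. The expected move is a step that the limit leaves unreadable from compound 2 to compound 3 on this estimate. Compound 3 is estimated at 15000 nM with an expected range from 7000 nM to 30000 nM and will most likely read as a limit again.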

Compound 3, half-maximal effective concentration: > 11000 nM
Compound 3 was reported as a limit; the forecaster's own chance of this, stated with the estimate: 80%; the middle value is on the limit's open side.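

Going by these compounds alone, compound 3 gives > 11000 nM, again only a limit, so no step among compound 1, compound 2 and compound 3 can be read in this assay. The compounds shown leave open where any exact value lies and whether changing the group on the carbonyl carbon shifts it: the limit of > 11000 nM in this assay, at which 3 of the 3 values shown sit.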